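Swapping a methyl for 4-methoxyphenyl on the amide nitrogen

The source may report more compounds than this note shows. Statements on the series, on what has been measured and on what is new or still open speak of the compounds shown alone.

Of the compounds shown here, three sharing one core have been tested in a functional assay on the whole organism for inhibition, with Rattus norvegicus as the target, read by paw edema, at a dose of 100 mg/kg by the oral route; on this read-out lower numbers stand for less inhibition and higher numbers for more inhibition at the one dose given (going by the name of the read-out). Compound 1, `CNC(=O)c1c(O)c2cccnc2n(-c2ccccc2)c1=O`, gives 9.6% in this assay. Compound 2, `CN(C)CCNC(=O)c1c(O)c2cccnc2n(-c2ccccc2)c1=O`, gives 22.6%, and compound 3, `O=C(Nc1ccccc1)c1c(O)c2cccnc2n(-c2ccccc2)c1=O`, gives 4.6%. Among these three numbers compound 1 stands second highest: compound 3 lies nearest, and compound 2 lies furthest, as the step of a number 13 percentage points higher from compound 1 to compound 2 (beyond the scatter) shows.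

The compound now in question is compound 4, `COc1ccc(NC(=O)c2c(O)c3cccnc3n(-c3ccccc3)c2=O)cc1`. It differs from compound 1 in one place: 4-methoxyphenyl in place of methyl on an amide-type nitrogen.

The step that bears most directly on this change is a number 5 percentage points lower from compound 1 to compound 3 (within the scatter), in which an aromatic ring likewise replaced the methyl on the amide-type nitrogen. That step stayed within the usual scatter. Within the data shown here, the step of a number 18 percentage points lower from compound 2 to compound 3 (beyond the scatter) is less closely related, and no other pair of measured compounds resembles the change at hand. On this basis compound 4 is expected to behave much like compound 3, so the step of a number 3.6 percentage points lower from compound 1 to compound 4 (within the scatter) is expected to be small and, if anything, downward. For compound 4 the estimated inhibition is 6%, with a range from -5% to 18%.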

Compound 4, a percentage reported as inhibition, in the whole organism at one dose (the size of the read-out at that dose, not a potency): 0.3%
Beside the measured number, compound 4's estimate is 5.7 percentage points above it; low and high end bracket the measured number.
By their numbers in this assay, from the lowest: compounds 4, 3 and 1 (each within the scatter of the next); then compound 2.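

In this assay, placing methoxy on the aromatic ring attached to the amide nitrogen gives no change that can be told from the usual scatter (a number 4.3 percentage points lower from compound 3 to compound 4 (within the scatter)). Replacing the methyl with the larger 4-methoxyphenyl group also stays within the scatter (a number 9.3 percentage points lower from compound 1 to compound 4 (within the scatter)), so these compounds show no clear effect of either change at this position, while the gap to the compound with the 2-(dimethylamino)ethyl chain lies beyond it (a number 22.3 percentage points lower from compound 2 to compound 4 (beyond the scatter)), as it did for the plain phenyl compound. No measurement is available to explain these numbers.

The compounds shown leave open whether the higher number of compound 2 depends on the dimethylamino group or on the saturated chain that carries it, a question that a 2-methoxyethyl chain on the same nitrogen could help to separate. They also do not show whether a longer chain such as 3-(dimethylamino)propyl, a ring amine such as morpholine, or a carboxylic acid on the phenyl ring would move the number beyond the scatter.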